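The compounds below may be only part of what the source reports. "The series", "measured", "known", "first", "only" and "open" are said of these compounds alone.

In a physicochemical assay for solubility, in phosphate buffer, measured as kinetic solubility, at pH 7.4 (on this read-out higher numbers stand for higher solubility and lower numbers for lower solubility), two compounds have been measured so far. Compound 1 `Cc1oc(-c2c(Cl)cccc2Br)nc1CN1CCC(C(=O)NCCCN2C[C@H](C)C[C@H](C)C2)CC1` and compound 2 `COc1cccc(Br)c1-c1nc(CN2CCC(C(=O)NCCCN3C[C@H](C)C[C@H](C)C3)CC2)c(C)o1` share one core. Compound 1 gives > 83 ug/mL as its reading, which is a limit of the assay and not a number. Compound 2 gives > 83 ug/mL as its reading, which is again only a limit and not a number. The data so far amount to the limit of > 83 ug/mL in this assay, at which 2 of the 2 values shown sit, and nothing finer, so compound 2 has no exact position on the scale. Compound 3 `COc1cccc(Cl)c1-c1nc(CN2CCC(C(=O)NCCCN3C[C@H](C)C[C@H](C)C3)CC2)c(C)o1` has not yet been measured. It departs from compound 2 by chloro in place of bromo on an aromatic carbon and so carries chloro in place of bromo on an aromatic carbon, ortho to a large group and meta to a methoxy group. Within the data shown here, the only measured step that bears on this is a step that the two limits leave unreadable from compound 1 to compound 2 and it offers no size to carry over. No step beyond the scatter is therefore expected in this assay and no direction is favoured. The estimated step is a step that the limit leaves unreadable from compound 2 to compound 3 in size. Compound 3 is expected at 85 ug/mL within an estimated range of 60 ug/mL to 100 ug/mL and will quite likely be reported only as a limit.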

Compound 3, solubility: > 76 ug/mL
Compound 3: no number, only a limit; the forecaster's own chance of this, stated with the estimate: 85%; the middle value is on the limit's open side.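

In this assay compound 3 gives > 76 ug/mL, which is a limit of the assay and not a number. Among these compounds, the readings of compound 1, compound 2 and compound 3 are all limits, and no step between them can be read. Going by these compounds, how far each compound lies past its limit, and whether swapping bromo, chloro or methoxy matters here, stays open.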